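Semicarbazone series: cytotoxicity on fibroblasts, compound 4 outlook

This account rests on a few compounds, and the source may have more. Where it says the series, first, only, none or still open, it means among the compounds named here.

Measured so far:
compound 1 `COc1ccc(/C=N/NC(=O)Nc2ccc(Oc3ccnc(-c4nncn4CCN(C)C)c3)c(F)c2)c(OC)c1` — 6630 nM
compound 2 `CN(C)CCn1cnnc1-c1cc(Oc2ccc(NC(=O)N/N=C/c3ccc(O)c(O)c3)cc2F)ccn1` — "not determined" (no result reported)
compound 3 `CN(C)CCn1cnnc1-c1cc(Oc2ccc(NC(=O)N/N=C/c3cc(Br)c(O)c(Br)c3)cc2F)ccn1` — "not determined" (no result reported)

The series shares one core and varies only the aryl group on the carbon with a double bond to nitrogen. In an ADME assay on WI-38 cells (Homo sapiens) for cytotoxicity, read by MTT assay, with a stated time of 72 h (a lower number here means a stronger inhibitor, a higher number a weaker inhibitor), compound 1 gives 6630 nM. For compound 2 the result in this assay is "not determined" (no result reported), and for compound 3 the result in this assay is likewise "not determined" (no result reported). Compound 3 therefore stands without a number of its own, and compound 2 is the one further entry in the same position; the only anchor for the series in this assay is compound 1.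

Compound 4 `COc1cc(/C=N/NC(=O)Nc2ccc(Oc3ccnc(-c4nncn4CCN(C)C)c3)c(F)c2)ccc1O` follows from compound 3 by 4-hydroxy-3-methoxyphenyl in place of 3,5-dibromo-4-hydroxyphenyl on a carbon with a double bond to nitrogen. For the measured compounds named here, no step between two measured compounds exists here, so the size of the change on going to compound 4 cannot be read from the data. The expectation is for no step beyond the usual scatter in this assay, in no particular direction, with compound 1 as the only reference point.

For compound 4 the estimate in this assay is 7000 nM, expected to lie between 2000 nM and 25000 nM.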

Compound 4, half-maximal inhibitory concentration: 5320 nM
Beside the measured number, compound 4's estimate is 1.3-fold (0.12 log units) above it, within the range that was stated.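

In this assay, for the compounds shown here, 4-hydroxy-3-methoxyphenyl in place of 2,4-dimethoxyphenyl on a carbon with a double bond to nitrogen gives the only readable step, a 1.2-fold lower number from compound 1 to compound 4 (0.10 log units; within the scatter), so this read-out does not separate these two aryl groups and the place now has a second reference point in addition to the single anchor it had before. The steps involving compound 2 or compound 3 cannot be read, which leaves the exchange of 3,5-dibromo-4-hydroxyphenyl for 4-hydroxy-3-methoxyphenyl without a size in this assay. No measured evidence is available that bears on this result.

With one readable pair, both members carrying oxygen substituents on the aryl ring, the compounds shown do not tell how far this place can be varied before the number in this assay moves beyond the scatter. Open in particular is whether an aryl group carrying an amine or a carboxylic acid on the carbon with a double bond to nitrogen would stay within the scatter of these values.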